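This account rests on a few compounds, and the source may have more. Where it says the series, first, only, none or still open, it means among the compounds named here.

In a functional assay on MGC-803 cells (Homo sapiens) for antiproliferative activity, read by CellTiter-Glo, with a stated time of 72 h (a lower number here means a stronger inhibitor, a higher number a weaker inhibitor), compound 1 `O=C(NO)c1ccc(/C=C/c2ccnc(-c3cc(F)ccc3O)c2)cc1` gives 1920 nM, compound 2 `O=C(NO)c1ccc(/C=C/c2ccnc(-c3cccc(O)c3)c2)cc1` gives 2100 nM and compound 3 `COc1ccc(-c2cc(/C=C/c3ccc(C(=O)NO)cc3)ccn2)cc1` gives 3510 nM. Compound 3 therefore stands within the scatter of both other compounds, as shown by a 1.8-fold higher number from compound 1 to compound 3 (0.26 log units; within the scatter) and a 1.7-fold higher number from compound 2 to compound 3 (0.22 log units; within the scatter). The third measured step, a 1.1-fold higher number from compound 1 to compound 2 (0.04 log units; within the scatter), is also within the scatter.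

Compound 4 `O=C(NO)c1ccc(/C=C/c2ccnc(Br)c2)cc1` carries bromo in place of 4-methoxyphenyl, next to the ring nitrogen: bromo in place of 4-methoxyphenyl on an aromatic carbon. The three measured steps bear on this change only indirectly. Each exchanges one substituted phenyl group for another, and none replaces that group with a single atom. They show that this assay changed little across these phenyl groups, but they do not test the loss of the ring, so the data give no direction for the change. No shift beyond the scatter is therefore expected, although the uncertainty is wide. The estimated change is a 1.0-fold lower number from compound 3 to compound 4 (0.00 log units; within the scatter). For compound 4, the expected value is 3500 nM, with an estimated range of 1200 nM to 10000 nM.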

Compound 4, half-maximal inhibitory concentration: > 10000 nM
Compound 4 was reported as a limit (the forecaster's own chance of this, stated with the estimate: 5%); at least 2.8-fold (0.45 log units) between middle value and limit.
By their numbers in this assay, from the lowest: compounds 1, 2 and 3 (each within the scatter of the next). At a limit, above all of these: compound 4.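

Compound 4 stands in this assay only as a limit and not as a number: the limit of > 10000 nM in this assay, at which 1 of the 4 values shown sits. The earlier steps shown here exchanged one substituted phenyl group for another and stayed within the scatter, whereas bromo on this carbon next to the ring nitrogen gives an at least 2.8-fold higher number from compound 3 to compound 4 (0.45 log units; beyond the scatter), an at least 4.7-fold higher number from compound 2 to compound 4 (0.67 log units; beyond the scatter) and an at least 5.2-fold higher number from compound 1 to compound 4 (0.71 log units; beyond the scatter). The position therefore responds to this change as it did not among the three phenyl groups, and each of these steps gives only a lower bound on the true size.

The compounds shown leave open whether the loss of the ring or the presence of bromine accounts for this step. A morpholine, an amine or a short alkyl chain at this position would help separate the two.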